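Replacing a difluorocyclohexenyl ring with an oxygen-containing ring

A few compounds are considered here, and "the series" means these few. Any claim that something is new, unique, unknown or untested is made for them only; others in the source may bear on it.

Measured so far:
compound 1, `Cc1cc(NCc2ccccn2)n2ncc(-c3cccc(Cl)c3)c2n1`, < 5000 nM
compound 2, `Cc1cc(NCc2ccccn2)n2ncc(C3=CCC(F)(F)CC3)c2n1`, 5000 nM

Going by the values given here, compound 2 is the only member of this small set with a real number: in a physicochemical assay for solubility, read by HPLC, using the shake flask method, measured as kinetic solubility, with a stated time of 2 h, at pH 7.4 (on this read-out higher numbers stand for higher solubility and lower numbers for lower solubility), compound 2 gives 5000 nM. For compound 1 this assay reports only a limit, < 5000 nM, so the step of a number no lower from compound 1 to compound 2 (the limit leaves the size open) cannot be sized; the limit of < 5000 nM in this assay, at which 1 of the 2 values shown sits, is where one of the two values sits.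

Compound 3, `Cc1cc(NCc2ccccn2)n2ncc(C3=CCOCC3)c2n1`, is not yet measured. It differs from compound 2 by a group of 6 heavy atoms (5 carbon, 1 oxygen; one six-membered non-aromatic ring with 1 hetero atom) in place of a group of 8 heavy atoms (6 carbon, 2 fluorine; one six-membered non-aromatic ring of carbon only), on an aromatic carbon. Among the compounds with values here, no measured step bears directly on this change: the only step seen exchanges a 3-chlorophenyl for the 4,4-difluorocyclohex-1-en-1-yl, which is a different pair of groups, and its size is not readable.

Within the data shown here, with no step to go on, compound 3 is expected to sit close to compound 2 in this assay, with the step of a 1.6-fold higher number from compound 2 to compound 3 (0.20 log units; within the scatter) estimated to stay within the usual scatter or only a little beyond it. The estimate for compound 3 is therefore 8000 nM, with a range from 3000 nM to 30000 nM.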

Compound 3, solubility: 171000 nM
The estimate for compound 3 lay 21-fold (1.33 log units) below the measured number; measured number above the stated range.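

In this assay, going by these compounds alone, the earlier compounds gave only a step that could not be sized, whereas this exchange of one six-membered non-aromatic ring for another, on an aromatic carbon of a five-membered aromatic ring with 2 nitrogen, gives a 34-fold higher number from compound 2 to compound 3 (1.53 log units; beyond the scatter). Set against the 3-chlorophenyl group, the same oxygen-containing ring gives an at least 34-fold higher number from compound 1 to compound 3 (1.53 log units; beyond the scatter), so the read-out at this position is clearly not indifferent to the group placed there, and both steps lie beyond the scatter. The second step rests on a value for compound 1 that is a limit and not a number: the limit of < 5000 nM in this assay, at which 1 of the 3 values shown sits.

Within the data shown here, the single exchange between compound 2 and compound 3 changes several things at once, since the ring oxygen enters while the fluorine atoms leave, so these compounds cannot separate the share of each. They also leave open whether the step is particular to the ring oxygen or would also appear with a ring nitrogen, as in a tetrahydropyridine ring carrying an amine, or with a fully saturated tetrahydropyran ring at the same carbon.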